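The compounds below may be only part of what the source reports. "The series", "measured", "known", "first", "only" and "open" are said of these compounds alone.

Measured compounds:
- compound 1 `COc1ccc(-c2cc(/C=C/C(=O)c3ccc(N)cc3)[nH]n2)cc1` — 1480 nM
- compound 2 `COc1ccc(-c2cc(/C=C/C(=O)c3ccc(N)cc3)[nH]n2)cc1OC` — 3110 nM
- compound 3 `COc1cc(C(=O)/C=C/c2cc(-c3cc(OC)c(OC)c(OC)c3)n[nH]2)cc(OC)c1OC` — 1780 nM

All three values come from a functional assay on UACC-62 cells (Homo sapiens) for inhibition, read by sulforhodamine B assay, with a stated time of 48 h; on this read-out lower numbers stand for stronger inhibition of growth and higher numbers for weaker inhibition of growth. Among the compounds with values here, the one counted step within the measured set runs from compound 2 to compound 1: hydrogen in place of methoxy on an aromatic carbon gives a 2.1-fold lower number from compound 2 to compound 1 (0.32 log units; beyond the scatter). Compound 3 and compound 2 share the same kind of core, but the difference between the two cores is not broken down here.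

Compound 4 `COc1ccc(-c2cc(/C=C/C(=O)c3cc(OC)c(OC)c(OC)c3)[nH]n2)cc1OC` is not yet measured. It follows from compound 3 by hydrogen in place of methoxy on an aromatic carbon. This is the same kind of change as that from compound 2 to compound 1, though in compound 3 the place is also meta to a methoxy group, which is not so in compound 2. Because a 2.1-fold lower number from compound 2 to compound 1 (0.32 log units; beyond the scatter) marks the only measured occurrence of this kind of change, compound 4 is expected to move in the same direction and by about the same amount, a 2.1-fold lower number from compound 3 to compound 4 (0.32 log units; beyond the scatter). Compound 4 is estimated at 850 nM, with a likely range from 400 nM to 1800 nM.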

Compound 4, concentration for 50% growth inhibition: 1790 nM
The estimate for compound 4 lay 2.1-fold (0.32 log units) below the measured number; low and high end bracket the measured number.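

In this assay, hydrogen in place of methoxy on an aromatic carbon gives a 1.0-fold higher number from compound 3 to compound 4 (0.00 log units; within the scatter). Set beside the earlier step, this result cannot be told apart from it across the two cores: the same change on two cores in this assay, a 2.1-fold lower number (0.32 log units; beyond the scatter) from compound 2 to compound 1 and a 1.0-fold higher number (0.00 log units; within the scatter) from compound 3 to compound 4, 2.1-fold (0.32 log units) apart, within the scatter of two such steps. Two steps, only one of them beyond the scatter, do not establish that the change keeps a fixed size from core to core, nor do they show that the two cores respond differently.

The compounds shown leave open how a hydroxy group or a fluorine atom would compare with methoxy and hydrogen at this place. They also leave open how the same change would read on a third core.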